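This account rests on a few compounds, and the source may have more. Where it says the series, first, only, none or still open, it means among the compounds named here.

Three compounds have so far been measured in an ADME assay on 184B5 cells (Homo sapiens) for cytotoxicity, read by MTT assay, with a stated time of 72 h; on this read-out higher numbers stand for weaker inhibition of growth and lower numbers for stronger inhibition of growth:

compound 1 `COc1ccc(CNc2nc(SC)nc3ncccc23)cc1`: 69800 nM
compound 2 `[SeH]c1nc(NCc2ccccc2)c2ccccc2n1`: 63600 nM
compound 3 `CCCCC[Se]c1nc(NCc2ccc(SC)cc2)c2ccccc2n1`: > 100000 nM, a limit of the assay

Of the two numbers, compound 1 gives the higher one, yet compound 2 lies within the usual scatter of it, so the pair cannot be told apart. For compound 3 the assay reports only a limit, (the limit of > 100000 nM in this assay, at which 1 of the 3 values shown sits). Compound 4 `CSc1nc(NCc2ccccc2)c2cccnc2n1` differs from compound 1 in a single place: hydrogen in place of methoxy on an aromatic carbon. No measured pair isolates this change, so nothing shown tells how it acts in this assay. On the values of compound 1 and compound 2, the expected step of a 1.1-fold higher number from compound 1 to compound 4 (0.03 log units; within the scatter) is small, no larger than the scatter, in either direction. Compound 4 is therefore estimated at 75000 nM, within a range of 30000 nM to 150000 nM.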

Compound 4, concentration for total growth inhibition: > 100000 nM
Compound 4 gave a limit, no number (the forecaster's own chance of this, stated with the estimate: 25%); at least 1.3-fold (0.12 log units) between middle value and limit.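

Hydrogen in place of methoxy on an aromatic carbon, para to a large group, now has a measured pair in this assay, and it gives an at least 1.4-fold higher number from compound 1 to compound 4 (0.15 log units; that floor lies within the scatter). Within this pair, losing the methoxy brings no stronger inhibition of growth. The true size of the step stays hidden, as compound 4 sits at a limit: the limit of > 100000 nM in this assay, at which 2 of the 4 values shown sit.

Going by these compounds, whether an amine, a chlorine or a longer alkoxy chain at this place would give a number below the limit remains open. So does whether this change acts alike on other cores.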